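Compound 1 to compound 3: methyl on the amine nitrogen

The source may hold more compounds than are shown below. What is called first, only, known or untested is meant among the compounds shown, and "the series" means these compounds.

In a functional assay on B16 cells (Mus musculus) for inhibition, read by MTT assay, with a stated time of 72 h (a higher number here means a weaker inhibitor, a lower number a stronger inhibitor), compound 1 (`CN(C)c1ccc(/C=C2\CNC/C(=C\c3ccc(N(C)C)cc3)C2=O)cc1`) gives 32500 nM and compound 2 (`CCN(CC)c1ccc2cc(/C=C3\CNC/C(=C\c4cc5ccc(N(CC)CC)cc5oc4=O)C3=O)c(=O)oc2c1`) gives 44000 nM as a pair within the scatter of each other. Compound 3 (`CN1C/C(=C\c2ccc(N(C)C)cc2)C(=O)/C(=C/c2ccc(N(C)C)cc2)C1`) has methyl in place of hydrogen on an amine nitrogen in a ring and otherwise matches compound 1. Within the data shown here, no measured pair shows this change, so no step beyond the scatter is expected in this assay and neither direction is favoured. The estimated 1.1-fold lower number from compound 1 to compound 3 (0.03 log units; within the scatter) is therefore small. Compound 3 is expected at 30000 nM (estimated range 12000 nM to 70000 nM).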

Compound 3, half-maximal inhibitory concentration: 23500 nM
Compound 3: middle estimate off by 1.3-fold (0.11 log units), on the high side, and the stated range covers the measured number.
By their numbers in this assay, from the lowest: compounds 3, 1 and 2 (each within the scatter of the next).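

In this assay the step of a 1.4-fold lower number from compound 1 to compound 3 (0.14 log units; within the scatter) lies within the scatter, so methyl in place of hydrogen on this amine nitrogen gives no readable change. The earlier compounds shown here all carry hydrogen at this position and could not show this. No measurement at hand bears on the result.

Open, going by these compounds, is whether a larger group on this nitrogen, such as benzyl or acetyl, would give a step beyond the scatter. Also open, on these data alone, is whether methyl at this position behaves the same way on the core of compound 2.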